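Swapping an Aryl Ether for a Branched Alkyl Ether

The source may hold more compounds than are shown below. What is called first, only, known or untested is meant among the compounds shown, and "the series" means these compounds.

Two compounds have been measured in an assay on HEK293 cells for inhibition of N-acylethanolamine-hydrolyzing acid amidase (Rattus norvegicus), read by LC-MS, with a stated time of 30 min; a higher number here means a weaker inhibitor, a lower number a stronger inhibitor:

Compound 1, `COc1cccc(CCCCCC(=O)N2CCOC2=O)c1`: 16300 nM
Compound 2, `Cc1cccc(Oc2ccc(C(=O)N3CCOC3=O)cc2)c1`: 5210 nM

Compound 2 holds the lowest number of the two, and compound 1 sits well above it, a gap beyond the usual scatter of the measurement. Compound 3, `CCC(CC)Oc1ccc(C(=O)N2CCOC2=O)cc1`, has not yet been tested. Compared with compound 2, it carries pentan-3-yl in place of 3-methylphenyl on an oxygen on an aromatic ring. An aromatic ring is thus removed and a branched five-carbon chain takes its place on the same oxygen, while the rest of the molecule is unchanged. Going by the values given here, no pair of measured compounds shows a change of this kind, so the two values above give no direct guide to its effect. The expectation is a modest move toward a higher number, a step of about a 1.5-fold higher number from compound 2 to compound 3 (0.19 log units; within the scatter), which could still fall within the scatter. Compound 3 is therefore expected to give roughly 8000 nM in this assay, with a plausible range from 2500 nM to 25000 nM.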

Compound 3, half-maximal inhibitory concentration: 480 nM
Beside the measured number, compound 3's estimate is 17-fold (1.22 log units) above it, outside the stated range (below it).
By their numbers in this assay, from the lowest: compound 3; then compound 2; then compound 1.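

In this assay, the group on the oxygen on the aromatic ring proves to have a strong influence on inhibition: pentan-3-yl in place of 3-methylphenyl gives an 11-fold lower number from compound 2 to compound 3 (1.04 log units; beyond the scatter), a large step beyond the usual scatter. For this pair, an aromatic ring at this place is therefore not required, and a smaller group with no ring gives the stronger inhibitor, something compound 1 could not reveal because it differs from compound 2 in more than one place. No supporting measurement is available to explain why this change has so large an effect.

As far as these compounds go, how a straight pentyl chain, an isopropyl group or a cyclopentyl ring on the same oxygen would compare remains open, so the step cannot yet be assigned to the branching, the chain length or the loss of the aromatic ring. Also open, from the compounds shown here alone, is whether replacing the oxygen itself with a nitrogen-containing amine link would keep the gain seen with compound 3, since that atom stays the same across this step.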